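The compounds below may be only part of what the source reports. "The series", "measured", "known", "first", "only" and "open" are said of these compounds alone.

Three compounds have been measured in a functional assay on SK-OV-3 cells (Homo sapiens) for inhibition, read by sulforhodamine B assay, with a stated time of 48 h; on this read-out higher numbers stand for weaker inhibition of growth and lower numbers for stronger inhibition of growth:

compound 1, `COc1ccc2[nH]c(-c3ccccc3)c(C=C(C#N)C#N)c2c1`: 4800 nM
compound 2, `COc1ccc(-c2[nH]c3ccc(OC)cc3c2/C=C(\C#N)S(=O)(=O)c2ccccc2)cc1`: 901 nM
compound 3, `CC(=O)/C(=C\c1c(-c2ccccc2)[nH]c2ccccc12)S(=O)(=O)c1ccccc1`: 2900 nM

Compound 3 gives the second-highest of the three numbers. Its nearest neighbour is compound 1, whose number lies within the usual scatter of the read-out, so the two cannot be told apart on these data. Compound 2, which carries a methoxy group on both its core and its attached phenyl ring as well as the sulfonyl side chain, gives a lower number than compound 3, and that gap lies beyond the scatter.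

Compound 4, `O=C(/C(=C\c1c(-c2ccccc2)[nH]c2ccccc12)S(=O)(=O)c1ccccc1)c1ccccc1`, has not yet been tested. It is compound 3 with one change: phenyl in place of methyl on a carbonyl carbon. For the measured compounds named here, none of the measured pairs shows this same change, so there is no step in this assay to draw on, and the expectation rests only on the size of the change and the spread of the three numbers seen so far. A step of this kind is expected to stay within the scatter, with no clear direction. Compound 4 is therefore estimated at 2500 nM, with a likely range from 900 nM to 7000 nM, which means an expected step of a 1.2-fold lower number from compound 3 to compound 4 (0.06 log units; within the scatter).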

Compound 4, concentration for 50% growth inhibition: 7600 nM
For compound 4 the middle estimate is 3.0-fold (0.48 log units) below the measured one; measured number outside the range, above it.
By their numbers in this assay, from the lowest: compound 2; then compounds 3, 1 and 4 (each within the scatter of the next, the first and the last beyond it).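

In this assay, replacing the acetyl of the side chain with a benzoyl gives a 2.6-fold higher number from compound 3 to compound 4 (0.42 log units; beyond the scatter), so the group on this carbonyl carbon does matter: a phenyl in place of a methyl weakens growth inhibition, although the step is modest. For the compounds shown here, this is the first comparison here in which only one place changes, whereas the earlier compounds differ in several places at once and so could not show what any single group contributes. Nothing available on these compounds explains why the number rises with this change.

With only methyl and phenyl shown on this carbonyl carbon, it remains open whether the loss grows steadily from small to large groups or belongs to the aromatic ring itself, and an ethyl chain, a cyclohexyl ring or a phenyl bearing an amine would help to separate those two readings. From the compounds shown here alone, it is also open whether the same change would give a step of similar size on a core carrying methoxy groups, like that of compound 2, which gives the lowest number of the four.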